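Propyl for methoxycarbonyl: compound 3 to compound 4

A few compounds are considered here, and "the series" means these few. Any claim that something is new, unique, unknown or untested is made for them only; others in the source may bear on it.

Values measured in a functional assay on Vero cells (Chlorocebus sabaeus) for inhibition (on this read-out lower numbers stand for stronger inhibition and higher numbers for weaker inhibition), are as follows:
- compound 1 `COc1cc(/C=C/C(=O)c2cccc(NC(=O)c3c(Cl)cccc3Cl)c2)ccc1O` gives 2.48 ug/mL
- compound 2 `COc1cc(/C=C/C(=O)c2cccc(NC(=O)c3ccc(Cl)cc3Cl)c2)ccc1O` gives 27.2 ug/mL
- compound 3 `COC(=O)C(=O)Nc1cccc(C(=O)/C=C/c2ccc(O)c(OC)c2)c1` gives 3.55 ug/mL

Compound 3 shares the low end of these numbers, with a 1.4-fold higher number from compound 1 to compound 3 (0.16 log units; within the scatter) and a 7.7-fold lower number from compound 2 to compound 3 (0.88 log units; beyond the scatter) as the steps leading to it. Compound 4 `CCCC(=O)Nc1cccc(C(=O)/C=C/c2ccc(O)c(OC)c2)c1` carries propyl in place of methoxycarbonyl on a carbonyl carbon. The remaining swap at that carbon gave an 11-fold higher number from compound 1 to compound 2 (1.04 log units; beyond the scatter), so replacements there have ranged from silent to large. Within the data shown here, none of the measured compounds carries propyl, so the range stays wide. In this assay the expected change is small and leans towards a higher number (a 1.5-fold higher number from compound 3 to compound 4 (0.19 log units; within the scatter)). Compound 4 is estimated at 5.5 ug/mL (range 1.8 ug/mL to 18 ug/mL).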

Compound 4, half-maximal inhibitory concentration: 2.04 ug/mL
For compound 4 the middle estimate is 2.7-fold (0.43 log units) above the measured one, and the stated range covers the measured number.
By their numbers in this assay, from the lowest: compounds 4, 1 and 3 (each within the scatter of the next); then compound 2.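

In this assay, propyl on the carbonyl carbon sits level with methoxycarbonyl (a 1.7-fold lower number from compound 3 to compound 4 (0.24 log units; within the scatter)) and with 2,6-dichlorophenyl (a 1.2-fold lower number from compound 1 to compound 4 (0.08 log units; within the scatter)), so among these compounds a chain with no ring and no oxygen serves as well as either group. The same swap from 2,4-dichlorophenyl gives a large step (a 13-fold lower number from compound 2 to compound 4 (1.12 log units; beyond the scatter)), which leaves compound 2 alone at the weak end of the four. No available measurement accounts for these steps. From the compounds shown here alone, whether a longer chain such as hexyl, an amine or a carboxylic acid on this carbonyl carbon would stay level with compound 4 remains open.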